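Moving a Fluorine on a Weakly Active Hydrazide Series

This account rests on a few compounds, and the source may have more. Where it says the series, first, only, none or still open, it means among the compounds named here.

Compound 1 `O=C(NNc1ccccc1F)c1cccc(NS(=O)(=O)c2cnc(O)nc2O)c1` and compound 2 `O=C(NNc1ccc(F)cc1)c1cccc(NS(=O)(=O)c2cnc(O)nc2O)c1` share one core and differ only by 4-fluorophenyl in place of 2-fluorophenyl on an amine nitrogen. In a functional assay on MDA-MB-231 cells (Homo sapiens) for antiproliferative activity, read by MTT assay, with a stated time of 24 h (a lower number here means a stronger inhibitor, a higher number a weaker inhibitor), compound 1 gives > 20000 nM, which is a limit of the measurement rather than a number. In this assay compound 2 gives > 20000 nM, again only a limit. The step that the two limits leave unreadable from compound 1 to compound 2 is therefore unreadable, because the limit of > 20000 nM in this assay, at which 3 of the 3 values shown sit, holds both values and the true gap between them could be anything.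

Compound 3 `O=C(NNc1ccccc1F)c1ccccc1NS(=O)(=O)c1cnc(O)nc1O` is built on a second core; the difference between the two cores is not broken down here. In this assay compound 3 gives > 20000 nM, once more a limit. Compound 4 `O=C(NNc1ccc(F)cc1)c1ccccc1NS(=O)(=O)c1cnc(O)nc1O` has not yet been measured and is related to compound 3 by 4-fluorophenyl in place of 2-fluorophenyl on an amine nitrogen, the same change that turns compound 1 into compound 2, made at the same place.

Among the measured compounds shown here, nothing measured so far moved a compound off the limit, and the one earlier example of this change left both partners there. For compound 4 the value in this assay is expected to be 30000 nM, within a range from 12000 nM to 100000 nM, resting on compound 3 at > 20000 nM and on the unreadable earlier step. The step from compound 3 to compound 4 is expected to be a step that the limit leaves unreadable from compound 3 to compound 4, most likely reported again only as a limit.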

Compound 4, half-maximal inhibitory concentration: > 20000 nM
Compound 4: no number, only a limit (the forecaster's own chance of this, stated with the estimate: 85%); the middle value lies beyond the limit too.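

In this assay compound 4 gives > 20000 nM, which is a limit and not a number. The step between compound 3 and compound 4 cannot be read, because both compounds sit at the same limit: the limit of > 20000 nM in this assay, at which 4 of the 4 values shown sit.

The compounds shown leave open whether 4-fluorophenyl in place of 2-fluorophenyl changes the activity at all on either core, and how far apart the true values of these compounds lie.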